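Swapping Methyl for Trifluoromethyl on a Sulfonate Ester

The compounds below may be only part of what the source reports. "The series", "measured", "known", "first", "only" and "open" are said of these compounds alone.

Compound 1 `C=C1C[C@]23C[C@@]1(O)CC[C@H]2c1ccc(OS(=O)(=O)c2ccc(C)cc2)c(C)c1[C@@H]3Cn1cc(-c2ccc(C)cc2)nn1` was tested in a functional assay on MCF7 cells (Homo sapiens) for cytotoxicity, read by MTT assay, with a stated time of 4 days; a higher number here means a weaker inhibitor, a lower number a stronger inhibitor. In this assay compound 1 gives only a limit, > 20000 nM, so its true strength is not known. Compound 3 `C=C1C[C@]23C[C@@]1(O)CC[C@H]2c1ccc(O)c(C)c1[C@@H]3Cn1cc(-c2ccc(C)cc2)nn1` also gives only a limit in this assay, > 20000 nM. The step from compound 1 to compound 3, a step that the two limits leave unreadable from compound 1 to compound 3, cannot be sized since (the limit of > 20000 nM in this assay, at which 2 of the 3 values shown sit). Compound 2 `C=C1C(=O)[C@]23C[C@@]1(O)CC[C@H]2c1ccc(O)c(C)c1[C@@H]3Cn1cc(-c2ccc(C(F)(F)F)cc2)nn1` differs from compound 3 in two places; in this assay compound 2 gives 1840 nM. Compound 4 `C=C1C[C@]23C[C@@]1(O)CC[C@H]2c1ccc(OS(=O)(=O)c2ccc(C)cc2)c(C)c1[C@@H]3Cn1cc(-c2ccc(C(F)(F)F)cc2)nn1` has not been measured; it differs from compound 1 by trifluoromethyl in place of methyl on an aromatic carbon. Within the data shown here, no measured step isolates this change, so the expectation rests on little. Compound 4 is expected to give about 12000 nM, between 2500 nM and 60000 nM, which would mean an expected step of an at least 1.6-fold lower number from compound 1 to compound 4 (0.22 log units; that floor lies within the scatter).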

Compound 4, half-maximal inhibitory concentration: > 20000 nM
Compound 4 ended at the assay's limit (the forecaster's own chance of this, stated with the estimate: 55%); middle value at least 1.6-fold (0.22 log units) from the limit.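

No step can be read between compound 1 and compound 4, because both give only a limit: the limit of > 20000 nM in this assay, at which 3 of the 4 values shown sit. Going by these compounds, whether trifluoromethyl in place of methyl changes strength at all in this assay stays open.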